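The source may hold more compounds than are shown below. What is called first, only, known or untested is meant among the compounds shown, and "the series" means these compounds.

Measured so far in a functional assay on HEK293 cells for agonist activity at Bombesin receptor subtype-3 (Homo sapiens), read by luminescence and calcium flux, with a stated time of 10 min; on this read-out higher numbers stand for an effect only at larger amounts of compound and lower numbers for an effect already at smaller amounts:
compound 1, `CCC(C)(C)Cc1c[nH]c(CCc2ccc(-c3cccc(C)n3)cc2)n1`: 105 nM
compound 2, `CCC(C)(C)Cc1c[nH]c(CCc2ccc(-n3cccn3)cc2)n1`: 135 nM
compound 3, `CCC(C)(C)Cc1c[nH]c(CCc2ccc(-n3ncnn3)cc2)n1`: 422 nM

Compound 3 stands at the highest number of the three. Its nearest neighbour is compound 2, a 3.1-fold higher number from compound 2 to compound 3 (0.49 log units; beyond the scatter); compound 1 lies furthest away, a 4.0-fold higher number from compound 1 to compound 3 (0.60 log units; beyond the scatter). The two lower numbers are close to each other, a 1.3-fold higher number from compound 1 to compound 2 (0.11 log units; within the scatter).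

Compound 4, `CCC(C)(C)Cc1c[nH]c(CCc2ccc(-c3ccc(F)cn3)cc2)n1`, is the next member of the series and differs from compound 3 in a single place: 5-fluoropyridin-2-yl in place of 2H-tetrazol-2-yl on an aromatic carbon. The entering group is a six-membered ring with one nitrogen, and so closer in kind to the group of compound 1 than to the five-membered rings of compound 2 and compound 3; it carries fluorine where compound 1 carries methyl.

For the measured compounds named here, the steps that bear on the change are those into the tetrazolyl compound: a 4.0-fold higher number from compound 1 to compound 3 (0.60 log units; beyond the scatter) and a 3.1-fold higher number from compound 2 to compound 3 (0.49 log units; beyond the scatter), both modest and both beyond the scatter. Running the change in reverse, a downward step of about the same size is expected for compound 4, a 3.2-fold lower number from compound 3 to compound 4 (0.51 log units; beyond the scatter), landing near the number of compound 1. Compound 4 is therefore estimated at 130 nM, with a range from 60 nM to 300 nM.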

Compound 4, half-maximal effective concentration: 66 nM
Compound 4: middle estimate off by 2.0-fold (0.29 log units), on the high side, within the range that was stated.
By their numbers in this assay, from the lowest: compounds 4, 1 and 2 (each within the scatter of the next, the first and the last beyond it); then compound 3.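

In this assay the 5-fluoropyridin-2-yl group, on this aromatic carbon para to a large group, more than recovers what 2H-tetrazol-2-yl gave up (a 6.4-fold lower number from compound 3 to compound 4 (0.81 log units; beyond the scatter)), so the position responds strongly to the choice of aromatic ring and tolerates a fluorine-bearing six-membered ring without loss. The two substituted pyridin-2-yl groups cannot be told apart here (a 1.6-fold lower number from compound 1 to compound 4 (0.20 log units; within the scatter)), so fluorine in place of methyl, at a different ring position, makes no readable difference between these two compounds. The new group also clears the five-membered 1H-pyrazol-1-yl (a 2.0-fold lower number from compound 2 to compound 4 (0.31 log units; beyond the scatter)), a separation that compound 1 did not show against compound 2, so a split of six-membered over five-membered rings holds for compound 4, while compound 1 goes against it.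

Open, on these data alone, is whether ring size or the count of hetero atoms tracks these numbers, and what an unsubstituted pyridin-2-yl, a plain phenyl ring or a morpholine ring would give at this place. Nothing at hand gives a reason for any of these steps.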